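Moving a Chloro Group on a Shared Core

The source may hold more compounds than are shown below. What is called first, only, known or untested is meant among the compounds shown, and "the series" means these compounds.

compound 1 `COc1cc(OC)cc(Sc2c[nH]c3ccccc23)c1` gives 25000 nM in an assay on isolated protein for inhibition of Indoleamine 2,3-dioxygenase 1 (Homo sapiens), read by HPLC, with a stated time of 60 min, in the presence of a further agent that is not named here; on this read-out higher numbers stand for weaker inhibition and lower numbers for stronger inhibition
compound 2 `COc1cc(OC)cc(Sc2c[nH]c3cc(Cl)ccc23)c1` gives 15000 nM in this assay

Among the measured compounds shown here, compound 1 holds the highest of the two numbers so far; its nearest neighbour is compound 2, with a 1.7-fold lower number from compound 1 to compound 2 (0.22 log units; within the scatter), a step within the scatter. Compound 3 `COc1cc(OC)cc(Sc2c[nH]c3c(Cl)cccc23)c1` has not yet been measured. It differs from compound 1 in one way: chloro in place of hydrogen on an aromatic carbon. For the measured compounds named here, the only measured step that bears on this is the one from compound 1 to compound 2, where the same group enters the shared core at a different aromatic carbon, giving a 1.7-fold lower number from compound 1 to compound 2 (0.22 log units; within the scatter), within the scatter. Nothing in the data shows that placing this group as in compound 3 would move the number beyond the scatter. Compound 3 is therefore expected to give about 20000 nM, between 8000 nM and 50000 nM, in this assay. The step so expected from compound 1 to compound 3 is a 1.3-fold lower number from compound 1 to compound 3 (0.10 log units; within the scatter).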

Compound 3, half-maximal inhibitory concentration: > 200000 nM
Compound 3: a limit, no number; the forecaster's own chance of this, stated with the estimate: 10%; at least 10-fold (1.00 log units) between middle value and limit.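

On the shared core, the effect of chloro in place of hydrogen depends on which aromatic carbon it occupies. At the carbon ortho to a fused ring and meta to a fused ring, the change gives an at least 8.0-fold higher number from compound 1 to compound 3 (0.90 log units; beyond the scatter), whereas at a different aromatic carbon it gave only a 1.7-fold lower number from compound 1 to compound 2 (0.22 log units; within the scatter). The value of compound 3 in this assay is a limit of the assay and not a number: the limit of > 200000 nM in this assay, at which 1 of the 3 values shown sits.

The compounds shown do not tell whether this weakening belongs to chloro alone or would also follow from a fluoro, methyl or methoxy group on the same carbon. They also leave open how far the true value of compound 3 lies past its limit, and so the full size of the step.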